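This account rests on a few compounds, and the source may have more. Where it says the series, first, only, none or still open, it means among the compounds named here.

In a functional assay on NCI-H460 cells (Homo sapiens) for inhibition, read by MTT assay, with a stated time of 72 h (on this read-out higher numbers stand for weaker inhibition and lower numbers for stronger inhibition), three compounds have been examined so far, and none of them has yielded a number. Compound 1 `O=c1[nH]c(=O)n(COC(CO)CO)cc1O` gives only a limit of the assay, > 100000 nM. Compound 2 `Cn1cc(CO)c(N)nc1=O` likewise gives only a limit, > 100000 nM. Compound 3 `Cc1cc(=O)[nH]c(=O)n1COC(CO)CO` also stops at a limit, > 100000 nM. Compound 3 therefore stands exactly where every value shown stands, namely at the limit of > 100000 nM in this assay, at which 3 of the 3 values shown sit, so nothing on these numbers separates it from compound 1 or compound 2.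

Compound 4 `Cc1c(I)c(=O)[nH]c(=O)n1COC(CO)CO` is the unmeasured partner of compound 3, and the change between the two is iodo in place of hydrogen on an aromatic carbon. Going by the values given here, no step between two measured compounds exists to gauge what this change does, and the three limits offer no direction. Compound 4 is thus expected to stay near the limit, with the step that the limit leaves unreadable from compound 3 to compound 4 amounting to nothing beyond the scatter. For compound 4 the estimate is 150000 nM, within 30000 nM and 600000 nM, with a fair chance that this assay once more reports only a limit.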

Compound 4, half-maximal inhibitory concentration: > 100000 nM
Compound 4 gave a limit, no number; the forecaster's own chance of this, stated with the estimate: 70%; the middle value is on the limit's open side.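

Compound 3 and compound 4 both end at a limit in this assay and so no step can be read between them, which is all this result shows: the limit of > 100000 nM in this assay, at which 4 of the 4 values shown sit. The compounds shown leave open whether any change to the shared core yields a measured number at all.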